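The source may hold more compounds than are shown below. What is called first, only, known or untested is meant among the compounds shown, and "the series" means these compounds.

Measured in an ADME assay on microsomes from liver (Rattus norvegicus) for metabolic stability, read by LC-MS, using NADPH, tested at 3 uM; a lower number here means that the compound disappears faster, a higher number that the compound lasts longer:

- compound 1 `N#CC(C#N)C(c1ccccc1)c1c(-c2ccccc2)[nH]c2ccccc12` gives 0.247 h
- compound 2 `N#CCC(c1ccccc1)c1c(-c2ccccc2)[nH]c2cc(Cl)ccc12` gives 0.375 h
- compound 3 `Cc1ccc2c(C(c3cccs3)C(C#N)C#N)c(-c3ccccc3)[nH]c2c1` gives 0.0817 h

Compound 1 cannot be separated from compound 2, while compound 3 gives a clearly lower number than compound 1, beyond the usual scatter.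

Compound 4 `O=C(C(c1ccccc1)c1c(-c2ccccc2)[nH]c2ccccc12)C(F)(F)F` has yet to be measured. It carries (trifluoromethyl)carbonyl in place of dicyanomethyl on a saturated chain carbon bound to two aromatic carbons and keeps the rest of compound 1 unchanged.

For the measured compounds named here, no two measured compounds differ in one place only, so the data offer no direct guide to this change, and no clear direction can be argued. The estimated change a 1.0-fold higher number from compound 1 to compound 4 (0.01 log units; within the scatter) is expected to stay within the scatter. For compound 4 the expected half-life is 0.25 h with an estimated range from 0.08 h to 0.8 h in this assay.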

Compound 4, half-life: 0.69 h
Beside the measured number, compound 4's estimate is 2.8-fold (0.44 log units) below it, and the stated range covers the measured number.
By their numbers in this assay, from the lowest: compound 3; then compounds 1, 2 and 4 (each within the scatter of the next, the first and the last beyond it).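

Swapping dicyanomethyl for (trifluoromethyl)carbonyl on a saturated chain carbon bound to two aromatic carbons gives the first single-change comparison at this position. In this assay it produces a 2.8-fold higher number from compound 1 to compound 4 (0.45 log units; beyond the scatter) and so counts as a modest step, which shows that the half-life of this series depends on the group held at this carbon. Nothing measured here accounts for the step. From the compounds shown here alone, whether an amine or a carboxylic acid at this carbon would shift the half-life further stays open. So does whether this swap would have the same effect with a thiophene ring or a chlorine elsewhere in the molecule.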